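Ethylamino to dimethylamino across two cores

A few compounds are considered here, and "the series" means these few. Any claim that something is new, unique, unknown or untested is made for them only; others in the source may bear on it.

Compound 1 `CCNCC(=O)Nc1cc(OC)ccc1C(=O)c1cc(OC)c(OC)c(OC)c1` and compound 2 `COc1ccc(C(=O)c2cc(OC)c(OC)c(OC)c2)c(NC(=O)CN(C)C)c1` share one core. In a functional assay on A549 cells (Homo sapiens) for antiproliferative activity, read by MTT assay, with a stated time of 48 h (a higher number here means a weaker inhibitor, a lower number a stronger inhibitor), compound 1 gives 750 nM and compound 2 gives 590 nM. The change between them, (dimethylamino in place of ethylamino on a saturated chain carbon bound to a carbonyl carbon), made a step of a 1.3-fold lower number from compound 1 to compound 2 (0.10 log units; within the scatter). Compound 3 `C=C(c1ccc2c(c1)C=CC(C)(C)O2)c1ccc(OC)cc1NC(=O)CNCC` sits on a different core; the difference between the two cores is not broken down here. In this assay compound 3 gives 1180 nM, which lies within the scatter of both compound 1 and compound 2. Compound 4 `C=C(c1ccc2c(c1)C=CC(C)(C)O2)c1ccc(OC)cc1NC(=O)CN(C)C` carries the same change on the core of compound 3, (dimethylamino in place of ethylamino on a saturated chain carbon bound to a carbonyl carbon), at the same place. Because the earlier step of a 1.3-fold lower number from compound 1 to compound 2 (0.10 log units; within the scatter) stayed within the scatter, a similarly small step is expected here, a 1.3-fold lower number from compound 3 to compound 4 (0.12 log units; within the scatter). Compound 4 is estimated at 900 nM, with a likely range from 450 nM to 1800 nM.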

Compound 4, half-maximal inhibitory concentration: 430 nM
Compound 4: middle estimate off by 2.1-fold (0.32 log units), on the high side, and the stated range ends above it.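

In this assay the change from ethylamino to dimethylamino on the core of compound 3 gives a 2.7-fold lower number from compound 3 to compound 4 (0.44 log units; beyond the scatter) and thus goes beyond the scatter, which the step on the core of compound 1 does not. Even so, the two steps cannot be told apart: the same change on two cores in this assay, a 1.3-fold lower number (0.10 log units; within the scatter) from compound 1 to compound 2 and a 2.7-fold lower number (0.44 log units; beyond the scatter) from compound 3 to compound 4, 2.2-fold (0.33 log units) apart, within the scatter of two such steps.
The change therefore carries from one core to the other without a measurable dependence on the core, but two cores do not show that the step keeps its size on others, and they do not explain it.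

Still open, going by these compounds, is whether a primary amine or a diethylamino group on the same saturated chain carbon would behave alike on both cores. On these data alone, a longer chain carrying the dimethylamino group is also open.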